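The source may hold more compounds than are shown below. What is called first, only, known or untested is meant among the compounds shown, and "the series" means these compounds.

In an assay on cells for inhibition of sodium- and chloride-dependent glycine transporter 1 (Homo sapiens) (on this read-out higher numbers stand for an effect only at larger amounts of compound and lower numbers for an effect already at smaller amounts), compound 1 `CN1CCCC(NC(=O)c2ccc(C(F)(F)F)cc2C(F)(F)F)(c2ccccc2)C1` gives 540 nM and compound 2 `CN1CCCC(NC(=O)c2ccc(C(F)(F)F)cc2Br)(c2ccccc2)C1` gives 300 nM; the step between them, a 1.8-fold lower number from compound 1 to compound 2 (0.26 log units; within the scatter), swaps one group on the aromatic part of the amide. Compound 3 `COc1cc(C(F)(F)F)cc(SC)c1C(=O)NC1(c2cccc(F)c2)CCCN(C)C1` gives 48 nM, the lowest of the three numbers, and its distance to each of the other two lies beyond the scatter. Compound 4 `COc1cc(C(F)(F)F)cc(SC)c1C(=O)NC1(c2ncccn2)CCCN(C)C1` differs from compound 3 in one place: pyrimidin-2-yl in place of 3-fluorophenyl on a saturated ring carbon. Within the data shown here, the only measured step, a 1.8-fold lower number from compound 1 to compound 2 (0.26 log units; within the scatter), concerns the aromatic amide side and not the saturated ring carbon, so no step bears directly on this change. A modest rise in the number is therefore expected, a 3.1-fold higher number from compound 3 to compound 4 (0.49 log units; beyond the scatter). For compound 4 the estimate is 150 nM, in a range from 40 nM to 600 nM.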

Compound 4, half-maximal effective concentration: > 10000 nM
Compound 4 ended at the assay's limit; the forecaster's own chance of this, stated with the estimate: 5%; middle value at least 66-fold (1.82 log units) away from the limit.
By their numbers in this assay, from the lowest: compound 3; then compounds 2 and 1 (each within the scatter of the next). At a limit, above all of these: compound 4.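

In this assay, the saturated ring carbon turns out to be highly sensitive to the group it carries: pyrimidin-2-yl in place of 3-fluorophenyl gives an at least 200-fold higher number from compound 3 to compound 4 (2.31 log units; beyond the scatter). Among these compounds, the one earlier step concerned the aromatic amide side, so this is the first view of a change at this position. The value of compound 4 is a limit of the assay and not a number: the limit of > 10000 nM in this assay, at which 1 of the 4 values shown sits. Still open, as far as these compounds go, is which part of the swap matters, the lost fluorine or the two ring nitrogens that enter. An unsubstituted phenyl or a pyridin-2-yl on this carbon would help to separate the two.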